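The source may hold more compounds than are shown below. What is called first, only, known or untested is meant among the compounds shown, and "the series" means these compounds.

Measured compounds in an ADME assay on HEK-293T cells (Homo sapiens) for inhibition, read by MTT assay, tested at 10 uM; on this read-out lower numbers stand for less inhibition and higher numbers for more inhibition at the one concentration tested (going by the name of the read-out):

Compound 1 `Cc1ccc2c(c1)CCN2S(=O)(=O)c1ccc(-c2cnc(C3CC3)o2)cc1` gives 74.7%.
Compound 2 `O=[N+]([O-])c1ccc2c(c1)CCN2S(=O)(=O)c1ccc(-c2cnc(C3CC3)o2)cc1` gives 48.4%.

Going by the values given here, compound 2 holds the lowest of the two numbers available; its nearest neighbour is compound 1, and the only measured step, a number 26.3 percentage points lower from compound 1 to compound 2 (beyond the scatter), sets the gap between them. Compound 3 `N#Cc1ccc2c(c1)CCN2S(=O)(=O)c1ccc(-c2cnc(C3CC3)o2)cc1` has not yet been measured in this assay. It differs from compound 2 in one place: cyano in place of nitro on an aromatic carbon.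

Among the compounds with values here, only one step is available as a reference, a number 26.3 percentage points lower from compound 1 to compound 2 (beyond the scatter), and it concerns a different exchange at the same aromatic carbon, methyl to nitro. Within the data shown here, no measured pair shows the exchange of nitro for cyano, so there is no direct guide to its size or direction. Among the measured compounds shown here, the one known step shows that a change of group at this carbon can move the read-out beyond the scatter, in that case downward. With cyano entering in place of nitro, compound 3 is estimated to land between the two measured values, with a step of a number 8.6 percentage points higher from compound 2 to compound 3 (within the scatter) expected. For compound 3 the estimate is 57%, with a range from 38% to 76%.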

Compound 3, a percentage reported as inhibition, at one concentration (the size of the read-out at that concentration, not a potency): 37.4%
Compound 3: middle estimate off by 19.6 percentage points, on the high side, outside the stated range (below it).
By their numbers in this assay, from the lowest: compound 3; then compound 2; then compound 1.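

In this assay, going by these compounds alone, cyano in place of nitro gives a number 11 percentage points lower from compound 2 to compound 3 (beyond the scatter) and so shows that nitro and cyano are told apart at this aromatic carbon, which the single earlier step, from methyl to nitro, could not show. Against the methyl of the first compound in the series, cyano gives a number 37.3 percentage points lower from compound 1 to compound 3 (beyond the scatter) and this is the widest gap among the three, so with every step beyond the scatter the order at this carbon runs from methyl at the top through nitro to cyano at the bottom. No measurement on hand gives a reason for this order.

The three compounds leave open where other groups would fall in this order at the same carbon, for example an amine, a carboxylic acid, a methoxy group, chlorine or plain hydrogen, and whether any of them would go lower than cyano. They also leave open whether the same order would hold with the cyclopropyl group on the far end of the shared core replaced, since all three compounds carry it unchanged.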